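Adding a Second Chloro: Expected Effect on Growth Inhibition

The source may report more compounds than this note shows. Statements on the series, on what has been measured and on what is new or still open speak of the compounds shown alone.

Measured compounds:
compound 1 `N#C/C(=C\N1CCN(C(=O)c2ccco2)C1=S)C(N)=O` gives 4000 nM
compound 2 `O=CN1CCN(c2ccc(Cl)cc2)C1=S` gives 21600 nM

In a functional assay on NCI-H460 cells (Homo sapiens) for inhibition, read by sulforhodamine B assay, with a stated time of 48 h (a higher number here means a weaker inhibitor of growth, a lower number a stronger inhibitor of growth), compound 1 gives 4000 nM, while compound 2 gives 21600 nM, the higher of the two numbers by a gap beyond the usual scatter, so compound 2 is the weaker growth inhibitor of this pair. Compound 3 `O=CN1CCN(c2ccc(Cl)c(Cl)c2)C1=S` differs from compound 2 by chloro in place of hydrogen on an aromatic carbon. For the measured compounds named here, no measured pair shows this change, so the expected step of a 1.4-fold lower number from compound 2 to compound 3 (0.16 log units; within the scatter) is small, toward a somewhat lower number, and may not exceed the scatter. Compound 3 is expected to give about 15000 nM in this assay, between 5000 nM and 45000 nM.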

Compound 3, concentration for 50% growth inhibition: 19200 nM
Beside the measured number, compound 3's estimate is 1.3-fold (0.11 log units) below it; low and high end bracket the measured number.
By their numbers in this assay, from the lowest: compound 1; then compounds 3 and 2 (each within the scatter of the next).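

In this assay chloro in place of hydrogen on the aromatic carbon ortho to the existing chloro group gives a 1.1-fold lower number from compound 2 to compound 3 (0.05 log units; within the scatter) and so stays within the scatter. For the compounds shown here, this is the first direct look at this change, and at this position a second chloro leaves compound 3 level with compound 2 in growth inhibition. Nothing available explains this result.

From the compounds shown here alone, whether an amine or a carboxylic acid at the same carbon would also leave the number level stays open. So does whether a second chloro would behave alike on another core.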